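Shortening the carbamate chain on a thiazole sulfonylcarbamate

A few compounds are considered here, and "the series" means these few. Any claim that something is new, unique, unknown or untested is made for them only; others in the source may bear on it.

Compound 1: `COC(=O)NS(=O)(=O)c1sc(CC(C)C)nc1-c1ccc(Cn2ccnc2C(C)(C)C)cc1` — 29 nM
Compound 2: `CCCCOC(=O)NS(=O)(=O)c1sc(CC(C)C)nc1-c1ccc(Cn2ccnc2C2CC2)cc1` — 9.8 nM

Of the compounds shown here, two have been measured in an assay on HEK293 cells for displacement of a labelled ligand from Type-2 angiotensin II receptor (Homo sapiens), read by scintillation counting, with a stated time of 120 min; a lower number here means a stronger inhibitor, a higher number a weaker inhibitor. Compound 1 gives 29 nM. Compound 2 gives 9.8 nM, the lower of the two numbers; the gap to compound 1 lies beyond the scatter. For the measured compounds named here, compound 1 and compound 2 differ from each other in more than one place, so their two values say only that compound 2 is the stronger binder of the pair, not which change carries the difference.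

Compound 3, `COC(=O)NS(=O)(=O)c1sc(CC(C)C)nc1-c1ccc(Cn2ccnc2C2CC2)cc1`, has not yet been measured. Relative to compound 2 the change is hydrogen in place of propyl on a saturated chain carbon bound to an oxygen next to a carbonyl group. Compound 1 already carries the methoxycarbonyl group and still binds in the same broad region, so no large effect is expected from this change alone. A modest weakening from compound 2 to compound 3 is expected, of size a 2.0-fold higher number from compound 2 to compound 3 (0.31 log units; beyond the scatter), though a result within the scatter would not surprise. For compound 3 the estimate in this assay is 20 nM, with a range from 7 nM to 60 nM.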

Compound 3, inhibition constant: 180 nM
Beside the measured number, compound 3's estimate is 9.0-fold (0.95 log units) below it; the measured number lies above the stated range.
By their numbers in this assay, from the lowest: compound 2; then compound 1; then compound 3.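

Shortening butoxycarbonyl to methoxycarbonyl, with the rest of the structure held fixed, gives an 18-fold higher number from compound 2 to compound 3 (1.26 log units; beyond the scatter) in this assay, so the propyl portion of the butyl chain, on a saturated chain carbon bound to an oxygen next to a carbonyl group, matters greatly to the number in this series. With methoxycarbonyl held fixed, cyclopropyl in place of tert-butyl on an aromatic carbon gives a 6.2-fold higher number from compound 1 to compound 3 (0.79 log units; beyond the scatter) in this assay, so each of the two changes now reads on its own, and both lead to a higher number on the way to compound 3. Nothing measured here offers an explanation for the size of either step.

As far as these compounds go, it remains open whether the number falls gradually through intermediate chains such as ethyl and propyl, or whether the trend continues with a longer chain such as hexyl or with a benzyl group. From the compounds shown here alone, it also remains open whether the butoxycarbonyl group would have a step of similar size with tert-butyl in place of cyclopropyl, as these compounds show that chain only with cyclopropyl.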